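A few compounds are considered here, and "the series" means these few. Any claim that something is new, unique, unknown or untested is made for them only; others in the source may bear on it.

The measured compounds:

Compound 1, `Cc1[nH]nc(N)c1-c1ccc2ccccc2c1`, gives in an assay on Sf9 cells for inhibition of inhibitor of nuclear factor kappa-B kinase subunit epsilon (Homo sapiens), read by ADP-Glo, with a stated time of 60 min (on this read-out higher numbers stand for weaker inhibition and lower numbers for stronger inhibition), the value > 100000 nM, which is a limit of the assay and not a number.
Compound 2, `Cc1[nH]nc(N)c1-c1ccc(OCc2ccccc2)cc1`, gives in this assay a value of 15400 nM.
Compound 3, `CCCC(=O)n1nc(C)c(-c2ccc(Cl)c(Cl)c2)c1N`, gives in this assay the value > 100000 nM, again a limit of the assay rather than a measured number.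

Compound 3 therefore stands at the edge of what this assay can report: it sits at the limit of > 100000 nM in this assay, at which 2 of the 3 values shown sit, together with compound 1, and only compound 2 of the three carries an actual concentration. Among the compounds with values here, no step between two measured compounds that differ in a single place is available, so nothing recorded here shows how a change of the kind made next has behaved before.

Compound 4, `Cc1nn(C(=O)c2cccnc2)c(N)c1-c1ccc(Cl)c(Cl)c1`, differs from compound 3 in one place: pyridin-3-yl in place of propyl on a carbonyl carbon. Within the data shown here, with no comparable step in hand, the expectation rests only on where compound 3 stands, and the change is expected to move the read-out by nothing beyond the usual scatter. Compound 4 is thus expected to give about 100000 nM in this assay, with a range from 25000 nM to 300000 nM, most likely again reported only as a limit. That estimate means an expected step from compound 3 to compound 4 of a number no higher from compound 3 to compound 4 (the limit leaves the size open).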

Compound 4, half-maximal inhibitory concentration: > 100000 nM
Compound 4 gave a limit, no number (the forecaster's own chance of this, stated with the estimate: 70%); the middle value sits exactly at the limit.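

Compound 3 and compound 4 both give only a limit of the assay and not a number, so no step can be read from compound 3 to compound 4: the limit of > 100000 nM in this assay, at which 3 of the 4 values shown sit.

The compounds shown leave open whether pyridin-3-yl in place of propyl on a carbonyl carbon changes the read-out in this assay at all.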